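A Shorter Branched Chain on the Shared Core

The source may report more compounds than this note shows. Statements on the series, on what has been measured and on what is new or still open speak of the compounds shown alone.

Measured compounds:
- compound 1 `CCCCCCOc1cccc(O)c1C(=O)/C=C/c1ccc(O)cc1`: > 30000 nM
- compound 2 `O=C(/C=C/c1ccc(O)cc1)c1c(O)cccc1OCCC1CCCCC1`: > 30000 nM
- compound 3 `CC(C)CCOc1cccc(O)c1C(=O)/C=C/c1ccc(O)cc1`: 10300 nM

All three were tested in a functional assay on MDA-MB-231 cells (Homo sapiens) for antiproliferative activity, read by sulforhodamine B assay; on this read-out lower numbers stand for stronger inhibition of growth and higher numbers for weaker inhibition of growth. For compound 1 the result is only a limit of this assay, > 30000 nM, not a number. For compound 2 the result is likewise only a limit, > 30000 nM. Compound 3 alone gives a number, 10300 nM. So compound 1 stands at the weak end of what is known, and it is not the only one there: the limit of > 30000 nM in this assay, at which 2 of the 3 values shown sit.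

Compound 4 `CC(C)COc1cccc(O)c1C(=O)/C=C/c1ccc(O)cc1` is not yet measured. It differs from compound 1 in one place: isopropyl in place of pentyl on a saturated chain carbon bound to an oxygen on an aromatic ring.

Within the data shown here, two measured steps bear on this. Both reach compound 3 from a compound sitting at the limit: an at least 2.9-fold lower number from compound 1 to compound 3 (0.46 log units; beyond the scatter) and an at least 2.9-fold lower number from compound 2 to compound 3 (0.46 log units; beyond the scatter). The step between the two limits, a step that the two limits leave unreadable from compound 1 to compound 2, gives no reading. Both readable steps shorten and branch the chain and lower the number beyond the scatter. The change to compound 4 shortens and branches the chain in the same way, so a lowering of at least modest size is expected.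

Compound 4 is therefore estimated at 10000 nM in this assay, within 3000 nM to 30000 nM, an expected step of an at least 3.0-fold lower number from compound 1 to compound 4 (0.47 log units; beyond the scatter).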

Compound 4, concentration for 50% growth inhibition: 3520 nM
Estimate against measurement, compound 4: 2.8-fold (0.45 log units) above, within the range that was stated.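

Among these compounds, compound 4, with its isobutoxy chain, gives the first step between two true numbers in this assay: a 2.9-fold lower number from compound 3 to compound 4 (0.47 log units; beyond the scatter). The earlier lowering therefore does not rest only on comparison with a limit, and shortening the chain on this oxygen lowers the number again. Against the two compounds at the limit the step is larger than any that could be read before, with an at least 8.5-fold lower number from compound 1 to compound 4 (0.93 log units; beyond the scatter) and an at least 8.5-fold lower number from compound 2 to compound 4 (0.93 log units; beyond the scatter), which makes compound 4 the strongest of the four, although compounds 1, 3 and 4 together show only a short run in which the number falls as the chain shortens from hexyl to isobutyl, and compound 2, with a cyclohexyl ring on its chain, cannot be placed in that run.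

As far as these compounds go, whether the number keeps falling with a still shorter chain, such as ethyl or methyl, or what an amine or a carboxylic acid at the end of the chain would do, remains open. The order of compound 1 and compound 2 cannot be read, because both sit at the same limit: the limit of > 30000 nM in this assay, at which 2 of the 4 values shown sit.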